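Hydrazone substituent change on the adenosine series

The source may report more compounds than this note shows. Statements on the series, on what has been measured and on what is new or still open speak of the compounds shown alone.

Compound 1 `Nc1nc(N/N=C/c2ccc[nH]2)nc2c1ncn2[C@@H]1O[C@H](CO)[C@@H](O)[C@H]1O` gives 8 nM in an assay on CHO-K1 cells for displacement of a labelled ligand from adenosine receptor A1 (Homo sapiens), read by scintillation counting, with a stated time of 60 min; a lower number here means a stronger inhibitor, a higher number a weaker inhibitor. Compound 2 `Nc1nc(N/N=C/C2CCCC2)nc2c1ncn2[C@@H]1O[C@H](CO)[C@@H](O)[C@H]1O` gives 5.6 nM in this assay; the step of a 1.4-fold lower number from compound 1 to compound 2 (0.15 log units; within the scatter) is the only one measured, and it lies within the scatter, so compound 2 and compound 1 are not separated on the numbers shown. Compound 3 `N#Cc1ccccc1/C=N/Nc1nc(N)c2ncn([C@@H]3O[C@H](CO)[C@@H](O)[C@H]3O)c2n1` differs from compound 2 by 2-cyanophenyl in place of cyclopentyl on a carbon with a double bond to nitrogen. Among the compounds with values here, the only step that bears on this change is the one from compound 1 to compound 2, where an aromatic five-membered group was exchanged for a saturated one without a shift beyond the scatter; nothing measured addresses a six-membered aromatic group carrying a nitrile. Within the data shown here, the expected step of a 1.8-fold higher number from compound 2 to compound 3 (0.25 log units; within the scatter) is therefore small, with a wide range because the single step of a 1.4-fold lower number from compound 1 to compound 2 (0.15 log units; within the scatter) gives no direction. Compound 3 is estimated at 10 nM, between 3 nM and 40 nM.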

Compound 3, inhibition constant: 2.9 nM
Estimate against measurement, compound 3: 3.4-fold (0.54 log units) above; the measured number lies below the stated range.
By their numbers in this assay, from the lowest: compounds 3, 2 and 1 (each within the scatter of the next, the first and the last beyond it).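

Within the data shown here, at the carbon with a double bond to nitrogen, 2-cyanophenyl is tolerated in this assay and gives a 2.8-fold lower number from compound 1 to compound 3 (0.44 log units; beyond the scatter) as the only step beyond the scatter, and a modest one. Against cyclopentyl the same group gives a 1.9-fold lower number from compound 2 to compound 3 (0.29 log units; within the scatter) and so leaves compound 3 and compound 2 unseparated, which means that a six-membered aromatic ring carrying a nitrile and a saturated five-membered ring of fewer heavy atoms both sit at this place without a step beyond the scatter. Nothing available explains either step.

Still open is what the nitrile contributes, since the compounds shown include no plain phenyl to compare with 2-cyanophenyl. Also open, from the compounds shown here alone, is how this place responds to a ring carrying an amine or a carboxylic acid, or to an open longer chain in place of a ring.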